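Hydroxyphenyl position and cytotoxicity in a three-aryl series

The source may hold more compounds than are shown below. What is called first, only, known or untested is meant among the compounds shown, and "the series" means these compounds.

Compound 1 `Oc1ccc(-c2cc(-c3cccs3)cc(-c3ccccc3O)n2)cc1` is a limit in a functional assay on T47D cells (Homo sapiens) for cytotoxicity, read by CCK-8 assay (on this read-out higher numbers stand for weaker inhibition and lower numbers for stronger inhibition), given as > 50000 nM. Compound 2 `Oc1ccc(-c2cc(-c3cccs3)cc(-c3cccc(O)c3)n2)cc1` gives 780 nM. The change 3-hydroxyphenyl in place of 2-hydroxyphenyl on an aromatic carbon produces an at least 64-fold lower number from compound 1 to compound 2 (1.80 log units; beyond the scatter); the number for compound 1 is only a limit (the limit of > 50000 nM in this assay, at which 1 of the 3 values shown sits). Compound 3 `Oc1cccc(-c2cc(-c3ccco3)cc(-c3ccccc3O)n2)c1` gives 820 nM, within the scatter of compound 2; the difference between the cores of compound 1 and compound 3 is not broken down here. Compound 4 `Oc1cccc(-c2cc(-c3ccco3)cc(-c3cccc(O)c3)n2)c1` is not yet measured. It differs from compound 3 by 3-hydroxyphenyl in place of 2-hydroxyphenyl on an aromatic carbon, the same kind of change as in compound 1 to compound 2, but here the place is meta to a 3-hydroxyphenyl group and to a furan-2-yl group rather than to a 4-hydroxyphenyl group and a thiophen-2-yl group. Resting on the step from compound 1 to compound 2 an at least 64-fold lower number from compound 1 to compound 2 (1.80 log units; beyond the scatter), a step of a 5.5-fold lower number from compound 3 to compound 4 (0.74 log units; beyond the scatter) is expected for compound 4. Compound 4 is estimated at 150 nM, between 30 nM and 800 nM.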

Compound 4, half-maximal inhibitory concentration: 3520 nM
Compound 4: middle estimate off by 23-fold (1.37 log units), on the low side, outside the stated range (above it).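

In this assay, 3-hydroxyphenyl in place of 2-hydroxyphenyl on the aromatic carbon next to the ring nitrogen produces a 4.3-fold higher number from compound 3 to compound 4 (0.63 log units; beyond the scatter). The same change therefore does not carry over between these two cores, in size or in direction: the same change on two cores in this assay, an at least 64-fold lower number (1.80 log units; beyond the scatter) from compound 1 to compound 2 and a 4.3-fold higher number (0.63 log units; beyond the scatter) from compound 3 to compound 4, at least 270-fold (2.43 log units) apart, beyond the scatter of two such steps

The cores differ in a thiophen-2-yl against a furan-2-yl group and a 4-hydroxyphenyl against a 3-hydroxyphenyl group, which of these differences goes with the reversal is not shown, and the value of compound 1 is only a limit: the limit of > 50000 nM in this assay, at which 1 of the 4 values shown sits.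

Going by these compounds alone, still open is how the change behaves on a core differing from either of these by only one of those groups. Also open, going by these compounds, is whether a methoxy group or an amine, in place of a hydroxyl on these phenyl rings, would keep the cytotoxicity.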